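A few compounds are considered here, and "the series" means these few. Any claim that something is new, unique, unknown or untested is made for them only; others in the source may bear on it.

Measured so far in a physicochemical assay for lipophilicity, at pH 7.4; on this read-out lower numbers stand for lower lipophilicity and higher numbers for higher lipophilicity:

- Compound 1 (`CCc1c(C)[nH]c2cc(OC)c(Cl)cc2c1=O`): 2.43
- Compound 2 (`CCc1c(C)[nH]c2cc(OC)c(Br)cc2c1=O`): 1.7

Of these two numbers, compound 1 holds the higher, and compound 2 lies clearly under it. The account now turns to compound 3 (`COc1cc2[nH]c(C)c(Br)c(=O)c2cc1Cl`), which has not yet been measured. It differs from compound 1 as follows: bromo in place of ethyl on an aromatic carbon. In words, this is bromo in place of ethyl on an aromatic carbon, and the chloro of compound 1 stays.

Within the data shown here, only one measured step bears on this change: a number 0.73 log units lower from compound 1 to compound 2 (beyond the scatter). That step is modest and beyond the scatter, but it is bromo in place of chloro, so the group leaving is a different one. Among the measured compounds shown here, no measured step shows what happens when ethyl leaves, and the evidence is therefore indirect. It supports only a slight lean downward in this assay, not a transfer of the full size of that step. The expected change is a number 0.18 log units lower from compound 1 to compound 3 (within the scatter), a small one that may not clear the scatter. For compound 3 the estimated value is 2.25, with an expected range from 1.65 to 2.85.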

Compound 3, distribution coefficient: 0
Estimate against measurement, compound 3: 2.25 log units above, and the stated range ends above it.
By their numbers in this assay, from the lowest: compound 3; then compound 2; then compound 1.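

In this assay, the carbon that carries ethyl in compound 1, ortho to a methyl group and two atoms from the ring nitrogen, proves far from neutral: bromo in place of ethyl there gives a number 2.43 log units lower from compound 1 to compound 3 (beyond the scatter), with the chloro of compound 1 kept. The earlier compounds had shown only a change at another place on the shared core, bromo in place of chloro, which gave a number 0.73 log units lower from compound 1 to compound 2 (beyond the scatter) and counts as modest, whereas this step counts as large. So the two compounds that carry a bromo in place of a group of compound 1 both fall in this assay, and the size of the fall depends on which group leaves and where. Nothing measured here explains why this change has so large an effect.

The compounds shown do not separate the loss of ethyl from the arrival of bromo, as a single step changes both at once. Among these compounds, no compound with a chloro, a methyl group, a propyl chain or an amine on this carbon has been measured. Such compounds would show whether other replacements of ethyl also give a number this low.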